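This account rests on a few compounds, and the source may have more. Where it says the series, first, only, none or still open, it means among the compounds named here.

For the measured compounds named here, only two compounds have numbers so far in a functional assay on A498 cells (Homo sapiens) for inhibition, read by sulforhodamine B assay, with a stated time of 48 h; on this read-out lower numbers stand for stronger inhibition of growth and higher numbers for weaker inhibition of growth. Compound 1 (`COc1cc(-c2nn(-c3cccc(NC(=O)c4cccc(C(F)(F)F)c4)c3)cc2-c2ccncc2)ccc1Cl`) gives 687 nM and compound 2 (`O=C(Nc1cccc(-n2cc(-c3ccncc3)c(-c3ccc(Cl)c(O)c3)n2)c1)Nc1cc(C(F)(F)F)cc(C(F)(F)F)c1`) gives 792 nM in this test, and these two values lie within the scatter of each other. Compound 1 therefore stands level with compound 2. Compound 3 (`COc1cc(-c2nn(-c3cccc(NC(=O)c4ccccc4)c3)cc2-c2ccncc2)ccc1Cl`) is still unmeasured. It is compound 1 with hydrogen in place of trifluoromethyl on an aromatic carbon, on the ring of the benzoyl group. Going by the values given here, no measured pair isolates this change, so its size cannot be read from the data. Compound 1 at 687 nM and compound 2 at 792 nM both carry trifluoromethyl, and compound 3 has none, so a moderate weakening of growth inhibition is expected. The expected change is a 2.2-fold higher number from compound 1 to compound 3 (0.34 log units; beyond the scatter) in this assay and is only a rough estimate. Compound 3 is estimated at 1500 nM with an expected range from 600 nM to 4500 nM in this test.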

Compound 3, concentration for 50% growth inhibition: 361 nM
Estimate against measurement, compound 3: 4.2-fold (0.62 log units) above; measured number below the stated range.
By their numbers in this assay, from the lowest: compounds 3, 1 and 2 (each within the scatter of the next, the first and the last beyond it).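

For the compounds shown here, this is the first measured pair that isolates one change: on the benzoyl group, 3-(trifluoromethyl)phenyl gives way to phenyl, and in this assay the move reads a 1.9-fold lower number from compound 1 to compound 3 (0.28 log units; within the scatter) in this single place. Trifluoromethyl at this position is therefore not needed for growth inhibition in this test, since compound 3, with only hydrogen on that aromatic carbon, stands level with compound 1. Nothing is available that would explain this result.

Going by these compounds, whether a different group at this place, such as an amine, a nitrile or a carboxylic acid, would shift the number beyond the scatter remains open, since this pair sets only hydrogen against trifluoromethyl. Also open, on these data alone, is whether the same exchange would read alike on the other aromatic carbons of that ring.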